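Swapping a hydroxy for an amino on a second core

This account rests on a few compounds, and the source may have more. Where it says the series, first, only, none or still open, it means among the compounds named here.

Compound 1 `COc1ccc(C(=O)c2ccc(OC)c3c2C=CC(C)(C)O3)c(NC(=O)CO)c1` and compound 2 `COc1ccc(C(=O)c2ccc(OC)c3c2C=CC(C)(C)O3)c(NC(=O)CN)c1` share one core and differ in a single spot: amino in place of hydroxy on a saturated chain carbon bound to a carbonyl carbon. In a functional assay on A2780 cells (Homo sapiens) for antiproliferative activity, read by MTT assay, with a stated time of 48 h (a higher number here means a weaker inhibitor, a lower number a stronger inhibitor), compound 1 gives 420 nM, while compound 2 gives 890 nM, so the change made a 2.1-fold higher number from compound 1 to compound 2 (0.33 log units; beyond the scatter).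

Compound 3 `C=C(c1ccc(OC)cc1NC(=O)CO)c1ccc(OC)c2c1C=CC(C)(C)O2` carries the same hydroxy-bearing side chain on a different core; the difference between the two cores is not broken down here. In this assay compound 3 gives 280 nM, which sits within the scatter of compound 1 but beyond it relative to compound 2.

Compound 4 `C=C(c1ccc(OC)cc1NC(=O)CN)c1ccc(OC)c2c1C=CC(C)(C)O2` has not yet been measured. It is built from compound 3 by the same change that separated compound 1 from compound 2: amino in place of hydroxy on a saturated chain carbon bound to a carbonyl carbon. The expectation, resting on the step seen between compound 1 and compound 2 in this assay, is that the number rises by a comparable amount, an estimated 2.1-fold higher number from compound 3 to compound 4 (0.32 log units; beyond the scatter). Compound 4 is therefore expected to give about 590 nM, plausibly between 300 nM and 1200 nM.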

Compound 4, half-maximal inhibitory concentration: 400 nM
Compound 4: middle estimate off by 1.5-fold (0.17 log units), on the high side; the range from low to high includes it.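

In this assay, the same swap of hydroxy for amino on the second core gives a 1.4-fold higher number from compound 3 to compound 4 (0.15 log units; within the scatter), a step too small to tell apart from the spread of repeated measurements. Set side by side, the steps on the two cores do not differ by more than such measurements would allow, so the result fits a change that carries across from one core to the other: the same change on two cores in this assay, a 2.1-fold higher number (0.33 log units; beyond the scatter) from compound 1 to compound 2 and a 1.4-fold higher number (0.15 log units; within the scatter) from compound 3 to compound 4, 1.5-fold (0.17 log units) apart, within the scatter of two such steps. For the compounds shown here, this does not show that the step has the same size on both cores, since only one of the two steps lies beyond the scatter, and two cores are too few to make a rule for the whole series.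

The compounds shown leave open how a dimethylamino group or a carboxylic acid would read on a saturated chain carbon bound to a carbonyl carbon. They also leave open whether a longer chain carrying the hydroxy or amino group would give similar steps on these two cores.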